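The source may hold more compounds than are shown below. What is called first, only, known or untested is meant among the compounds shown, and "the series" means these compounds.

Compounds measured so far in a functional assay on A549 cells (Homo sapiens) for cytotoxicity, read by MTT assay, with a stated time of 68 h; a higher number here means a weaker inhibitor, a lower number a stronger inhibitor:

- compound 1 `O=C(Nc1cccc(-c2ccccc2C(F)(F)F)c1)C(Cl)Cl`: 7500 nM
- compound 2 `O=C(Nc1cccc(-c2ccccc2F)c1)C(Cl)Cl`: 13200 nM

Compound 2, at 13200 nM, sits within the usual scatter of compound 1, at 7500 nM, so these two values cannot be told apart in this assay. The next compound, compound 3 `O=C(Nc1cccc(-c2ccccc2Cl)c1)C(Cl)Cl`, differs from compound 2 at a single place, with chloro in place of fluoro on an aromatic carbon, ortho to a large group: chloro in place of fluoro on an aromatic carbon.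

Going by the values given here, only one measured step bears on this change: a 1.8-fold higher number from compound 1 to compound 2 (0.25 log units; within the scatter). It is also a swap of one group for another on an aromatic carbon, and it stays within the scatter. Among the compounds with values here, one small step is thin evidence, and no measured compound yet carries chloro. Even so, the swap from trifluoromethyl to fluoro gave no clear change, so no clear change is expected here either. The expected shift is a 1.3-fold lower number from compound 2 to compound 3 (0.12 log units; within the scatter), a size that would not stand out from the scatter. For compound 3 the estimated value is 10000 nM, with an expected range from 5000 nM to 20000 nM.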

Compound 3, half-maximal inhibitory concentration: 22600 nM
Compound 3: middle estimate off by 2.3-fold (0.35 log units), on the low side; measured number above the stated range.
By their numbers in this assay, from the lowest: compounds 1, 2 and 3 (each within the scatter of the next, the first and the last beyond it).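

In this assay, chloro in place of fluoro on the aromatic carbon ortho to a large group gives a 1.7-fold higher number from compound 2 to compound 3 (0.23 log units; within the scatter) and so does not separate these two groups. Going by these compounds alone, the comparison of compound 1 with compound 3 shows more: chloro in place of trifluoromethyl at this same place gives a 3.0-fold higher number from compound 1 to compound 3 (0.48 log units; beyond the scatter) and is the first step in this small set to lie beyond the scatter, though only modestly, with compound 3 the weaker inhibitor of that pair. Compound 2 stands within the scatter of both, so this position does respond to the group it carries, but the difference appears only between the two ends of the set, and nothing measured here explains it.

Three groups on one carbon give only a narrow view of this position, so it remains open whether an amine, a methoxy group or a carboxylic acid placed there would give a number outside the span of these compounds. Going by these compounds, it is also open whether the difference between trifluoromethyl and chloro would persist if the same groups sat elsewhere on the ring or if the rest of the core changed.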